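This account rests on a few compounds, and the source may have more. Where it says the series, first, only, none or still open, it means among the compounds named here.

In a functional assay for inhibition, with Homo sapiens as the target (a higher number here means a weaker inhibitor, a lower number a stronger inhibitor), compound 1 (`COC(=O)[C@@H](CC1CCCCC1)Nc1nc2ccccc2o1`) gives 100 nM and compound 2 (`Fc1ccc(C(CC2CCCCC2)Nc2nc3ccccc3o2)cc1`) gives 170 nM. These two values lie within the usual scatter of each other, so the numbers do not separate the two compounds. Compound 3 (`Cc1cccc(C(CC2CCCCC2)Nc2nc3ccccc3o2)c1`) is the next analogue to read. It carries 3-methylphenyl in place of 4-fluorophenyl on a saturated chain carbon bound to a nitrogen on an aromatic ring and a saturated chain carbon. Among the compounds with values here, the series holds no measured pair differing in one place, so no direct precedent exists for the size of this change. The expectation therefore starts from compound 2 at 170 nM, with no change beyond the scatter and no firm direction. The expected move in this assay is a 1.2-fold higher number from compound 2 to compound 3 (0.07 log units; within the scatter). For compound 3, the estimated value is 200 nM, with an expected range of 60 nM to 650 nM.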

Compound 3, half-maximal inhibitory concentration: 300 nM
The estimate for compound 3 lay 1.5-fold (0.18 log units) below the measured number; measured number inside the range.
By their numbers in this assay, from the lowest: compounds 1, 2 and 3 (each within the scatter of the next, the first and the last beyond it).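

In this assay, within the data shown here, the first single-place comparison reads as a 1.8-fold higher number from compound 2 to compound 3 (0.25 log units; within the scatter) and so does not separate the two aryl groups. At this saturated chain carbon bound to a nitrogen on an aromatic ring and a saturated chain carbon, 3-methylphenyl can therefore replace 4-fluorophenyl with no step beyond the scatter, while the heavy-atom count and the absence of hydrogen-bond donors and acceptors stay the same. No available evidence bears on this result.

This step alters both the substituent and its place on the ring, so the compounds shown cannot separate those two changes; 4-methylphenyl or 3-fluorophenyl would do so. Also open, as far as these compounds go, is whether the same carbon tolerates a group of another kind, such as a carboxylic acid or an amine-bearing chain.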